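The source may hold more compounds than are shown below. What is called first, only, known or untested is meant among the compounds shown, and "the series" means these compounds.

Measured compounds:
- compound 1, `COc1cc(/C=C/c2nc3cccnc3n(CC(=O)O)c2=O)ccc1O`: in a functional assay, read by spectrophotometry, with a stated time of 30 min, tested at 10 uM (a lower number here means a weaker effect, a higher number a stronger effect of the compound at the concentration tested), compound 1 gives 48.6%
- compound 2, `O=C(O)Cn1c(=O)c(-c2ccccc2)nc2cccnc21`: compound 2 gives "not determined" (no result reported)
- compound 3, `COc1ccc(/C=C/c2nc3cccnc3n(CC(=O)O)c2=O)cc1`: compound 3 gives "not determined" (no result reported)

Compound 1 is the only one of the three with a number in this assay; compound 2 and compound 3 carry no result, so nothing can be said about how they compare with it or with each other. The unmeasured compound 4, `COc1cc(/C=C/c2nc3cc(Br)cnc3n(CC(=O)O)c2=O)ccc1O`, keeps the shared core of compound 1 and differs from it in one place: bromo in place of hydrogen on an aromatic carbon. Within the data shown here, no pair of measured compounds differs in a single place, so there is no measured step to lean on. A bromine added on an aromatic carbon of a fused ring is a small change, and the expected shift from compound 1 in this assay is modest, most likely upward but not clearly beyond the usual scatter. The step from compound 1 to compound 4 is expected to be a number 6.4 percentage points higher from compound 1 to compound 4 (within the scatter). Compound 4 is therefore estimated at 55%, within a range from 30% to 80%.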

Compound 4, a percentage reported as activity, at one concentration (the size of the read-out at that concentration, not a potency): 59.6%
For compound 4 the middle estimate is 4.6 percentage points below the measured one; measured number inside the range.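

In this assay, bromo in place of hydrogen on this aromatic carbon gives a number 11 percentage points higher from compound 1 to compound 4 (beyond the scatter), the first measured step among these compounds. This shows that the position, two atoms from the ring nitrogen, tolerates a single bromine: the read-out at the concentration tested does not fall, and the rise is modest but larger than repeat measurements alone would usually produce. Nothing measured here bears on why the number rises.

This single step cannot show whether chloro, methyl or an amine on the same carbon would give a similar rise, or whether the rise depends on bromine itself. Going by these compounds, because each read-out comes from a single concentration, it also remains open whether the higher number would carry over to a difference in potency.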